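Amide to urea on the piperazine of a pteridine T-cell inhibitor

The source may hold more compounds than are shown below. What is called first, only, known or untested is meant among the compounds shown, and "the series" means these compounds.

Measured compounds:
compound 1 `COc1ccc(-c2cnc3nc(N)nc(N4CCN(C(=O)c5ccccc5)CC4)c3n2)cc1OC`: 400 nM
compound 2 `COc1ccc(-c2cnc3nc(N)nc(NC(C)C)c3n2)cc1OC`: 600 nM
compound 3 `CCOc1nc(N)nc2ncc(-c3ccc(OC)cc3)nc12`: > 10000 nM

In a functional assay on cells (T-cell, Homo sapiens) for inhibition (on this read-out lower numbers stand for stronger inhibition and higher numbers for weaker inhibition), compound 1 gives 400 nM and stands lowest of the two numbers reported. Compound 2 gives 600 nM in this assay, which lies within the scatter of compound 1, so no order between the two can be read. For compound 3 this assay returns only a limit, > 10000 nM, and not a number (the limit of > 10000 nM in this assay, at which 1 of the 3 values shown sits).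

Compound 4 `COc1ccc(-c2cnc3nc(N)nc(N4CCN(C(=O)Nc5cccc(C)c5)CC4)c3n2)cc1OC` has not yet been measured in this assay. It differs from compound 1 in one place: (3-methylphenyl)amino in place of phenyl on a carbonyl carbon. Going by the values given here, no measured pair shows the effect of such a change here, so the step from compound 1 to compound 4 is expected to be small, within or just beyond the scatter, with no clear direction. Compound 4 is estimated at 300 nM in this assay, the range 80 nM to 1200 nM, an expected step of a 1.3-fold lower number from compound 1 to compound 4 (0.12 log units; within the scatter).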

Compound 4, half-maximal inhibitory concentration: 7 nM
Compound 4: the middle estimate sits 43-fold (1.63 log units) above what was measured; the measured number lies below the stated range.
By their numbers in this assay, from the lowest: compound 4; then compounds 1 and 2 (each within the scatter of the next). At a limit, above all of these: compound 3.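

In this assay, going by these compounds alone, the group on the carbonyl carbon proves to be a strong lever on this read-out, something no earlier compound could show: (3-methylphenyl)amino in place of phenyl gives a 57-fold lower number from compound 1 to compound 4 (1.76 log units; beyond the scatter). The step is large and lies beyond the scatter. Nothing in the data shown accounts for its size. Within the data shown here, the single change brings in both the amino link and the methyl, so their shares cannot be separated. On these data alone, what phenylamino without the methyl would give stays open, as does the effect of benzylamino at this place.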